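The source may report more compounds than this note shows. Statements on the series, on what has been measured and on what is new or still open speak of the compounds shown alone.

Compound 1 `COc1cc(-c2cc3nccc(-c4c[nH]c5ccccc45)n3n2)cc(OC)c1OC` gives in a functional assay on MCF7 cells (Homo sapiens) for inhibition, read by CCK-8 assay, with a stated time of 48 h (on this read-out lower numbers stand for stronger inhibition and higher numbers for weaker inhibition), only a limit of the assay, > 10000 nM.
Compound 2 `COc1ccc(-c2cc3nccc(-c4cc(OC)c(OC)c(OC)c4)n3n2)cc1F` gives in this assay 183 nM.
Compound 3 `COc1cc(-c2ccnc3cc(-c4cn(C)c5ccccc45)nn23)cc(OC)c1OC` gives in this assay 95 nM.

Of the two numbers shown, compound 2 carries the one that stands beside compound 3, separated by a 1.9-fold lower number from compound 2 to compound 3 (0.28 log units; within the scatter). Compound 4 `COc1cc(-c2ccnc3cc(-c4cccc(C#N)c4)nn23)cc(OC)c1OC` differs from compound 2 at one place: 3-cyanophenyl in place of 3-fluoro-4-methoxyphenyl on an aromatic carbon. Among the compounds with values here, the only measured step that bears on this place, the exchange of the same aryl group between compound 2 and compound 3, gave a 1.9-fold lower number from compound 2 to compound 3 (0.28 log units; within the scatter). On that basis no step beyond the scatter is expected from compound 2 to compound 4; the expected step is a 1.0-fold lower number from compound 2 to compound 4 (0.01 log units; within the scatter). Compound 4 is therefore estimated at 180 nM, within a range from 60 nM to 550 nM.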

Compound 4, half-maximal inhibitory concentration: > 10000 nM
Compound 4: a limit, no number (the forecaster's own chance of this, stated with the estimate: 5%); at least 55-fold (1.74 log units) between middle value and limit.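

Putting 3-cyanophenyl in place of 3-fluoro-4-methoxyphenyl gives an at least 54-fold higher number from compound 2 to compound 4 (1.73 log units; beyond the scatter), and putting it in place of 1-methyl-1H-indol-3-yl gives an at least 100-fold higher number from compound 3 to compound 4 (2.02 log units; beyond the scatter). Compound 2 and compound 3 carry two quite different groups here and stay within the scatter of each other, yet this position on the five-membered aromatic ring clearly does not accept every aromatic group. The value of compound 4 is a limit of the assay, not a number: the limit of > 10000 nM in this assay, at which 2 of the 4 values shown sit.

Still open, from the compounds shown here alone, is whether a plain phenyl ring would keep the number low. The same holds for a phenyl ring carrying an amine or a carboxylic acid instead of the nitrile.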